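This account rests on a few compounds, and the source may have more. Where it says the series, first, only, none or still open, it means among the compounds named here.

In a functional assay on PC-3 cells (Homo sapiens) for inhibition, read by MTT assay, with a stated time of 48 h (on this read-out higher numbers stand for weaker inhibition and lower numbers for stronger inhibition), compound 1 `COc1ccc(-n2c(SCc3ccc(C)cc3)nnc2-c2cc(OC)c(OC)c(OC)c2)cc1` gives 56500 nM, and compound 2 `CCSc1nnc(-c2cc(OC)c(OC)c(OC)c2)n1-c1ccc(N(C)C)cc1` gives 46200 nM. Compound 3 `COc1ccc(CSc2nnc(-c3cc(OC)c(OC)c(OC)c3)n2-c2ccc(N(C)C)cc2)cc1` is reported only as a limit of the assay, > 60000 nM. This is the limit of > 60000 nM in this assay, at which 1 of the 3 values shown sits, so compound 3 has no exact number. Compound 4 `COc1cc(-c2nnc(SCc3ccc(C)cc3)n2-c2ccc(N(C)C)cc2)cc(OC)c1OC` differs from it by methyl in place of methoxy on an aromatic carbon, para to a large group. Among the measured compounds shown here, the only measured step bearing on this change is an at least 1.2-fold higher number from compound 2 to compound 3 (0.11 log units; that floor lies within the scatter), which involves the same 4-methoxybenzyl group. No step beyond the scatter is therefore expected in this assay, and no direction can be firmly assigned. The expected change is an at least 1.2-fold lower number from compound 3 to compound 4 (0.07 log units; that floor lies within the scatter). For compound 4 the estimate is 50000 nM, with an expected range from 28000 nM to 90000 nM.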

Compound 4, half-maximal inhibitory concentration: 37300 nM
Compound 4: middle estimate off by 1.3-fold (0.13 log units), on the high side, within the range that was stated.
By their numbers in this assay, from the lowest: compounds 4, 2 and 1 (each within the scatter of the next). At a limit, above all of these: compound 3.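

Compound 3 has no exact number in this assay: the limit of > 60000 nM in this assay, at which 1 of the 4 values shown sits. Methyl in place of methoxy at this position therefore gives only a floor, an at least 1.6-fold lower number from compound 3 to compound 4 (0.20 log units; that floor lies within the scatter), which does not establish the full size of the step. With 4-methylbenzyl in place, compound 4 has an exact value, and both a 1.2-fold lower number from compound 2 to compound 4 (0.09 log units; within the scatter) and a 1.5-fold lower number from compound 1 to compound 4 (0.18 log units; within the scatter) stay inside the scatter, so none of these single changes separates the compounds. Still open, as far as these compounds go, is whether an amine or a carboxylic acid on this aromatic carbon, or a longer chain on the sulfur, would produce a step beyond the scatter.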